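The source may hold more compounds than are shown below. What is called first, only, known or untested is meant among the compounds shown, and "the series" means these compounds.

Working notes on the series. Among the compounds with values here, in a functional assay on MCF7 cells (Homo sapiens) for inhibition, read by sulforhodamine B assay, with a stated time of 72 h (a higher number here means a weaker inhibitor, a lower number a stronger inhibitor), compound 3 `COc1ccc(C2=Nn3c(nnc3C(C)c3ccc(-c4ccccc4)c(F)c3)SC2)cc1` gives 2600 nM, the lowest of the three numbers so far; compound 1 `CC(c1ccc(-c2ccccc2)c(F)c1)c1nnc2n1N=C(c1ccc(OC(F)(F)F)cc1)CS2` gives 4800 nM and compound 2 `CC(c1ccc(-c2ccccc2)c(F)c1)c1nnc2n1N=C(c1ccc(Cl)cc1Cl)CS2` gives 7600 nM. The step of a 1.8-fold lower number from compound 1 to compound 3 (0.27 log units; within the scatter) stays within the scatter, whereas a 2.9-fold lower number from compound 2 to compound 3 (0.47 log units; beyond the scatter) is modest but beyond it. Compound 4 `CC(c1ccc(-c2ccccc2)c(F)c1)c1nnc2n1N=C(c1ccc(Cl)cc1)CS2` differs from compound 3 by chloro in place of methoxy on an aromatic carbon. The swaps measured so far at this position, a 1.6-fold higher number from compound 1 to compound 2 (0.20 log units; within the scatter) and a 2.9-fold lower number from compound 2 to compound 3 (0.47 log units; beyond the scatter), are small, and the nearest of them touches a chloro pattern that is not the same; no step beyond the scatter is therefore expected here, with the estimated step of a 1.5-fold higher number from compound 3 to compound 4 (0.16 log units; within the scatter) leaning, if anything, toward a higher number. For compound 4 the expected value in this assay is 3800 nM, with an estimated range from 1600 nM to 9000 nM.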

Compound 4, half-maximal inhibitory concentration: 8700 nM
Beside the measured number, compound 4's estimate is 2.3-fold (0.36 log units) below it, within the range that was stated.
By their numbers in this assay, from the lowest: compounds 3, 1, 2 and 4 (each within the scatter of the next, the first and the last beyond it).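

In this assay, within the data shown here, a change of the single group on the aromatic ring alone now carries a step beyond the scatter (a 3.3-fold higher number from compound 3 to compound 4 (0.52 log units; beyond the scatter)), where methoxy gives way to chloro. The second chloro of compound 2 shows no effect (a 1.1-fold higher number from compound 2 to compound 4 (0.06 log units; within the scatter)), and 4-chlorophenyl also stays within the scatter of 4-(trifluoromethoxy)phenyl (a 1.8-fold higher number from compound 1 to compound 4 (0.26 log units; within the scatter)), so 4-methoxyphenyl separates from both chloro-bearing rings but not from compound 1. No measurement at hand accounts for the gap between methoxy and chloro.

As far as these compounds go, whether an amine, a hydroxyl or a longer alkoxy chain at this place would fall with methoxy or with chloro remains open.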